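The source may hold more compounds than are shown below. What is called first, only, known or untested is meant among the compounds shown, and "the series" means these compounds.

In a functional assay on C6 cells (Rattus norvegicus) for cytotoxicity, read by MTT assay, with a stated time of 24 h (on this read-out higher numbers stand for weaker inhibition and lower numbers for stronger inhibition), compound 1 `Cn1cnnc1SCC(=O)N/N=c1/scc(-c2ccc([N+](=O)[O-])cc2)n1-c1ccccc1` has no single number to its name, only the entry "not determined" (no result reported). Compound 2 `O=C(CSc1ncccn1)N/N=c1/scc(-c2ccc([N+](=O)[O-])cc2)n1-c1ccccc1` carries the same kind of entry, "not determined" (no result reported). Compound 3 `Cn1nnnc1SCC(=O)N/N=c1/scc(-c2ccc([N+](=O)[O-])cc2)n1-c1ccccc1` gives > 200 ug/mL, and this is a limit, not a number. Among the measured compounds shown here, the only firm guide is therefore (the limit of > 200 ug/mL in this assay, at which 1 of the 3 values shown sits).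

Compound 4 `Cn1cnnc1SCC(=O)N/N=c1/scc(-c2ccccc2)n1-c1ccccc1` has yet to be measured in this assay. The change that leads to it is hydrogen in place of nitro on an aromatic carbon. In words, hydrogen stands in place of nitro on an aromatic carbon of a six-membered aromatic ring of carbon only, para to a large group, so that 4-nitrophenyl becomes phenyl.

For the measured compounds named here, no measured pair shows what this change does in this assay, and compound 1 offers no number to step from. The nearest anchor is compound 3, whose > 200 ug/mL is a limit. From that level, no step beyond the usual scatter is expected, and neither direction is favoured. A report of compound 4 as a limit would be no surprise.

For compound 4 the estimated value is 180 ug/mL, with an expected range from 60 ug/mL to 400 ug/mL.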

Compound 4, half-maximal inhibitory concentration: 68.3 ug/mL
For compound 4 the middle estimate is 2.6-fold (0.42 log units) above the measured one; measured number inside the range.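

No step can be read from the result for compound 4: in this assay compound 1 is entered as "not determined" (no result reported), which leaves the pair with no two numbers to compare. The compounds shown leave open what the change from 4-nitrophenyl to phenyl does in this assay.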